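The source may report more compounds than this note shows. Statements on the series, on what has been measured and on what is new or still open speak of the compounds shown alone.

Compound 3 `C[C@@H](O)[C@H](NC(=O)CN(c1ncnc2c1ncn2C1CCCCO1)C1CC1)C(=O)OCc1ccccc1` carries a 1-hydroxyethyl group on a saturated chain carbon bound to an amide-type nitrogen and a carbonyl carbon. In a functional assay on the whole organism (Tail, strain ICR) with Mus musculus as the target, in the tail flick test, with a stated time of 90 min, at a dose of 25 umol/kg by the oral route (a lower number here means a weaker effect, a higher number a stronger effect of the compound at the dose given), compound 3 gives 23.4%. Compound 1 `O=C(CN(c1ncnc2c1ncn2C1CCCCO1)C1CC1)NCC(=O)OCc1ccccc1`, which has hydrogen at that place, gives 25.9% in this assay, and the two numbers lie within the scatter of each other. Compound 2 `O=C(CN(c1nc(Cl)nc2[nH]cnc12)C1CC1)N[C@@H](CO)C(=O)O`, built on a different core, gives 43.9%, a number beyond the scatter higher than that of compound 3.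

Compound 4 `O=C(CN(c1ncnc2c1ncn2C1CCCCO1)C1CC1)N[C@@H](CC(=O)OCc1ccccc1)C(=O)OCc1ccccc1` differs from compound 3 in one place: (benzyloxycarbonyl)methyl in place of 1-hydroxyethyl on a saturated chain carbon bound to an amide-type nitrogen and a carbonyl carbon. Going by the values given here, the only measured step at this place is a number 2.5 percentage points lower from compound 1 to compound 3 (within the scatter), where adding the 1-hydroxyethyl group left the number unchanged within the scatter. That single step suggests the group at this place has little bearing on the read-out, though it says nothing direct about a much larger group such as (benzyloxycarbonyl)methyl. On that basis the estimated step is a number 0.6 percentage points higher from compound 3 to compound 4 (within the scatter), a change not expected to exceed the scatter. Compound 4 is therefore estimated at 24%, with a range from 11% to 38%.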

Compound 4, a percentage reported as activity, at one dose (the size of the read-out at that dose, not a potency): 25.1%
Beside the measured number, compound 4's estimate is 1.1 percentage points below it; low and high end bracket the measured number.
By their numbers in this assay, from the lowest: compounds 3, 4 and 1 (each within the scatter of the next); then compound 2.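

Swapping 1-hydroxyethyl for (benzyloxycarbonyl)methyl, with 11 heavy atoms in place of 3 and a six-membered aromatic ring added, gives in this assay a number 1.7 percentage points higher from compound 3 to compound 4 (within the scatter). Set against plain hydrogen at the same place, the group gives a number 0.8 percentage points lower from compound 1 to compound 4 (within the scatter), so hydrogen, 1-hydroxyethyl and (benzyloxycarbonyl)methyl all lie within the scatter of one another on this saturated chain carbon, even though the entering group carries an ester and a ring. No data are at hand to explain why the read-out stays level here.

On these data alone, whether an amine or a longer alkyl chain at this place would shift the number beyond the scatter remains open. Compound 2 differs from these compounds in more than one place, so its separate standing cannot be traced to any single change.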